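The source may hold more compounds than are shown below. What is called first, only, known or untested is meant among the compounds shown, and "the series" means these compounds.

Compound 1 `O=C(c1cccnc1)c1cc(Cl)cc(Cl)c1O`: 27000 nM
Compound 2 `O=C(c1cccnc1)c1cc(Cl)ccc1O`: 27000 nM

In a functional assay on Hep cells (Homo sapiens) for cytotoxicity, read by sulforhodamine B assay, with a stated time of 48 h (a lower number here means a stronger inhibitor, a higher number a weaker inhibitor), compound 2 gives 27000 nM, level with compound 1 at 27000 nM. Compound 3 `Cc1ccc(O)c(C(=O)c2cccnc2)c1` carries methyl in place of chloro on an aromatic carbon, para to a hydroxy group (methyl in place of chloro on an aromatic carbon). Among the compounds with values here, only one measured step bears on this change, and it swaps chloro for hydrogen rather than methyl: no change at the digits printed from compound 1 to compound 2 (within the scatter). Losing that chloro left the value unmoved, so no large shift is expected here, though the data hold no direct test of methyl. The expected result is a 1.0-fold higher number from compound 2 to compound 3 (0.02 log units; within the scatter), a step no larger than the scatter, in neither direction. Compound 3 is estimated at 28000 nM, within a range of 14000 nM to 55000 nM.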

Compound 3, half-maximal inhibitory concentration: 11000 nM
The estimate for compound 3 lay 2.5-fold (0.41 log units) above the measured number, and the stated range ends above it.
By their numbers in this assay, from the lowest: compound 3; then compounds 1 and 2 (each within the scatter of the next).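

In this assay the position para to a hydroxy group proves sensitive to what it carries: methyl in place of chloro gives a 2.5-fold lower number from compound 2 to compound 3 (0.39 log units; beyond the scatter) and this change moves the number beyond the scatter. The earlier loss of the other chloro gave no change at the digits printed from compound 1 to compound 2 (within the scatter) and so offered no sign of such a response. Nothing shown here accounts for the shift.

Still open, from the compounds shown here alone, is whether a lower number would follow from other groups at this position, such as an amine, a methoxy group or a longer chain like ethyl.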